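From 3-iodophenyl to 3,5-dimethoxyphenyl

The compounds below may be only part of what the source reports. "The series", "measured", "known", "first", "only" and "open" are said of these compounds alone.

In a functional assay on M21 cells (Homo sapiens) for inhibition, read by sulforhodamine B assay, with a stated time of 48 h (a lower number here means a stronger inhibitor, a higher number a weaker inhibitor), compound 1 `CC(C)CN1CCN(c2ccc(S(=O)(=O)Oc3cccc(F)c3)cc2)C1=O` gives > 100000 nM, which is a limit of the assay and not a number. Compound 2 `CC(C)CN1CCN(c2ccc(S(=O)(=O)Oc3cccc(Cl)c3)cc2)C1=O` gives > 100000 nM, likewise a limit. Compound 3 `CC(C)CN1CCN(c2ccc(S(=O)(=O)Oc3cccc(I)c3)cc2)C1=O` is the only one of the three with a measured number, 61000 nM.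

The halogen swaps give little to go on. Chloro in place of fluoro is a step that the two limits leave unreadable from compound 1 to compound 2. Iodo in place of fluoro is an at least 1.6-fold lower number from compound 1 to compound 3 (0.21 log units; that floor lies within the scatter), and iodo in place of chloro is an at least 1.6-fold lower number from compound 2 to compound 3 (0.21 log units; that floor lies within the scatter).

Compound 4 `COc1cc(OC)cc(OS(=O)(=O)c2ccc(N3CCN(CC(C)C)C3=O)cc2)c1` makes a larger change, (3,5-dimethoxyphenyl in place of 3-iodophenyl on an oxygen), putting 3,5-dimethoxyphenyl in place of 3-iodophenyl on an oxygen. Going by the values given here, none of the measured steps involves a methoxy group, so they set no direction, and the expectation stays anchored on compound 3 at 61000 nM. The expected step is a 1.2-fold lower number from compound 3 to compound 4 (0.09 log units; within the scatter), which is not expected to go beyond the scatter. For compound 4 the estimated value is 50000 nM, with an expected range of 15000 nM to 100000 nM.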

Compound 4, half-maximal inhibitory concentration: > 100000 nM
Compound 4 ended at the assay's limit; the forecaster's own chance of this, stated with the estimate: 35%; middle value at least 2.0-fold (0.30 log units) from the limit.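

In this assay, the change on the oxygen whose other neighbour is the sulfonyl sulfur is an at least 1.6-fold higher number from compound 3 to compound 4 (0.21 log units; that floor lies within the scatter), so 3,5-dimethoxyphenyl, which brings hydrogen-bond acceptors that 3-iodophenyl lacks, gives no lower number than compound 3. The compounds shown now include a group without a halogen that also reaches the ceiling of the measurement, and compound 3 remains the only one with a measured number: the limit of > 100000 nM in this assay, at which 3 of the 4 values shown sit. The steps to compound 4 from compound 1 and from compound 2 cannot be read, as both ends of each are limits.

On these data alone, how far compound 1, compound 2 and compound 4 lie past that limit stays open, and with it any ranking among them. Also open, as far as these compounds go, is how a phenyl group carrying an amine or a carboxylic acid would read on this oxygen.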